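The compounds below may be only part of what the source reports. "The series", "measured", "known", "first", "only" and "open" are said of these compounds alone.

Compound 1 `CCn1c(SCC(=O)Nc2ccc(/C(C)=N/O)cc2)nnc1-c1cc(OC)c(OC)c(OC)c1` and compound 2 `CCn1c(SCC(=O)Nc2ccc(C(C)=O)cc2)nnc1-c1cc(OC)c(OC)c(OC)c1` share one core and were both tested in a functional assay on the whole organism (strain albino) for inhibition, with Rattus norvegicus as the target, read by paw edema, with stated times of 30 min and 1 h, at a dose of 0.28 mmol/kg by the oral route; a higher number here means more inhibition at the dose given (going by the name of the read-out), a lower number less inhibition. In this assay compound 1 gives 29%, the lower of the two numbers; compound 2 gives 46%, and the step of a number 17 percentage points higher from compound 1 to compound 2 (beyond the scatter) lies beyond the scatter. Compound 3 `C=CCn1c(SCC(=O)Nc2ccc(/C(C)=N/O)cc2)nnc1-c1cc(OC)c(OC)c(OC)c1` has not yet been measured. It differs from compound 1 by vinyl in place of methyl on a saturated chain carbon bound to an aromatic nitrogen. Among the measured compounds shown here, the only measured step alters the group on an aromatic carbon, not the saturated chain carbon bound to the aromatic nitrogen, so it does not bear on this change, and no measured pair shows what an alteration at that chain carbon does. With nothing to point a direction, the expectation is for no step beyond the scatter, a number 3 percentage points higher from compound 1 to compound 3 (within the scatter). Compound 3 is therefore estimated at 32%, with a range from 15% to 50%.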

Compound 3, a percentage reported as inhibition, in the whole organism at one dose (the size of the read-out at that dose, not a potency): 49%
For compound 3 the middle estimate is 17 percentage points below the measured one; low and high end bracket the measured number.
By their numbers in this assay, from the lowest: compound 1; then compounds 2 and 3 (each within the scatter of the next).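

At the saturated chain carbon bound to the aromatic nitrogen, the change from ethyl to allyl, which is vinyl in place of methyl, gives in this assay a number 20 percentage points higher from compound 1 to compound 3 (beyond the scatter). Among the compounds shown here, this is the first sign that the group at this place matters for the inhibition of paw edema at the dose given, as the earlier pair only altered the group on an aromatic carbon. No measurement bears on the reason for this step.

On these data alone, whether the gain goes with the double bond or with the longer chain stays open, and a propyl group at this place would separate the two. As far as these compounds go, it is also open whether allyl gives a similar step with the carbonyl group of compound 2 on the aromatic carbon.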